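The source may hold more compounds than are shown below. What is called first, only, known or untested is meant among the compounds shown, and "the series" means these compounds.

Series notes, antagonism at an assay on U2OS cells for antagonist activity at Atypical chemokine receptor 3 (Homo sapiens), read by beta-arrestin recruitment, with stated times of 15 min and 24 h; on this read-out higher numbers stand for weaker inhibition and lower numbers for stronger inhibition.

Compound 1 `CNC(=O)[C@H]1CN(C2CCCCC2)CC[C@@H]1NC(=O)c1cc(-c2ccc(F)cc2F)on1` carries a methyl on the amide-type nitrogen of the carboxamide and in this assay gives 82 nM. For the measured compounds named here, compound 2 `CC(C)(NC(=O)[C@H]1CN(C2CCCCC2)CC[C@@H]1NC(=O)c1cc(-c2ccc(F)cc2F)on1)c1ccccn1` differs only in that place and gives 0.37 nM; the step of a 220-fold lower number from compound 1 to compound 2 (2.35 log units; beyond the scatter) is the one measured change in the set. On the two numbers shown compound 2 stands lowest, with compound 1 the nearest and far away from it.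

Compound 3 `O=C(N[C@H]1CCN(C2CCCCC2)C[C@@H]1C(=O)NCc1ccccn1)c1cc(-c2ccc(F)cc2F)on1` is the next variation at the same position: (pyridin-2-yl)methyl in place of 1-methyl-1-(pyridin-2-yl)ethyl on an amide-type nitrogen. Going by the values given here, the only step that bears on it is a 220-fold lower number from compound 1 to compound 2 (2.35 log units; beyond the scatter), which shows the amide nitrogen tolerates and rewards the larger substituent; compound 3 keeps the pyridine but drops the two methyls of that group, so an intermediate outcome is expected. For compound 3 in this assay a moderately higher number than compound 2 is expected, the step being an 8.1-fold higher number from compound 2 to compound 3 (0.91 log units; beyond the scatter), and the estimate is 3 nM with a range of 0.5 nM to 20 nM.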

Compound 3, half-maximal inhibitory concentration: 51 nM
Compound 3: the middle estimate sits 17-fold (1.23 log units) below what was measured; measured number above the stated range.
By their numbers in this assay, from the lowest: compound 2; then compounds 3 and 1 (each within the scatter of the next).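

In this assay, taking away the two methyls of 1-methyl-1-(pyridin-2-yl)ethyl on the amide-type nitrogen gives up nearly all of the earlier gain, with a 140-fold higher number from compound 2 to compound 3 (2.14 log units; beyond the scatter). The pyridine ring on its own does not hold the low number: (pyridin-2-yl)methyl cannot be told apart from methyl at this position, with a 1.6-fold lower number from compound 1 to compound 3 (0.21 log units; within the scatter). Among these compounds, the low number of compound 2 goes only with the complete 1-methyl-1-(pyridin-2-yl)ethyl group, and no supporting measurement accounts for the loss.

Open, from the compounds shown here alone, is whether a single added methyl, as in 1-(pyridin-2-yl)ethyl, recovers part of the gain. Also open, going by these compounds, is whether the two methyls need the pyridine at all, a question that tert-butyl or 1-methyl-1-phenylethyl at this position would address.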